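This account rests on a few compounds, and the source may have more. Where it says the series, first, only, none or still open, it means among the compounds named here.

Working notes on the series. Within the data shown here, the three measured members share one core and differ at a single aromatic carbon. Compound 1 `Brc1cn2ccnc2c(-c2ccc3ncn(C4CCCCC4)c3c2)n1` carries bromo there; in a functional assay on EKVX cells (Homo sapiens) for inhibition, read by sulforhodamine B assay, with a stated time of 48 h, tested at 10 uM (on this read-out higher numbers stand for more inhibition at the one concentration tested (going by the name of the read-out) and lower numbers for less inhibition), compound 1 gives 12%. Compound 2 `c1ccc2c(-c3cn4ccnc4c(-c4ccc5ncn(C6CCCCC6)c5c4)n3)cccc2c1` carries naphthalen-1-yl, and in this assay compound 2 gives 13.3%. Compound 3 `Fc1ccc(-c2cn3ccnc3c(-c3ccc4ncn(C5CCCCC5)c4c3)n2)cc1` carries 4-fluorophenyl, and in this assay compound 3 gives 10.5%, the lowest of the three numbers, though the three cannot be told apart: a number 1.3 percentage points higher from compound 1 to compound 2 (within the scatter), a number 1.5 percentage points lower from compound 1 to compound 3 (within the scatter), a number 2.8 percentage points lower from compound 2 to compound 3 (within the scatter).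

Compound 4 `Brc1ccc(-c2cn3ccnc3c(-c3ccc4ncn(C5CCCCC5)c4c3)n2)cc1` is the next member to be tested. (bromo in place of fluoro on an aromatic carbon). Among the measured compounds shown here, no measured pair shows an exchange of one halogen for another on the phenyl group; the nearest comparison is bromo to 4-fluorophenyl on an aromatic carbon, which was within the scatter, as were the other two steps. Every change made so far at this carbon has left the read-out where it was, so the swap of bromo for fluoro is expected to do the same, giving a number 0.5 percentage points higher from compound 3 to compound 4 (within the scatter) and no step beyond the scatter. For compound 4 in this assay the expected value is 11%, between 3% and 19%.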

Compound 4, a percentage reported as inhibition, at one concentration (the size of the read-out at that concentration, not a potency): 16.2%
Beside the measured number, compound 4's estimate is 5.2 percentage points below it, within the range that was stated.
By their numbers in this assay, from the lowest: compounds 3, 1, 2 and 4 (each within the scatter of the next).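

In this assay, among these compounds, the exchange of one halogen for another on the phenyl group, on the aromatic carbon para to a large group, gives a number 5.7 percentage points higher from compound 3 to compound 4 (within the scatter) and so stays inside the usual spread of the measurement; this is the first look at a change on the phenyl group itself rather than at the carbon of the shared core. Among the compounds shown here, at that core carbon, 4-bromophenyl gives a number 4.2 percentage points higher from compound 1 to compound 4 (within the scatter) and a number 2.9 percentage points higher from compound 2 to compound 4 (within the scatter) in this comparison, so a fourth group there also cannot be told apart from the others, and no step among the four compounds lies beyond the scatter. No measurement is at hand that bears on why these numbers sit where they do.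

All four numbers come from one concentration in one cell line, so they say nothing about potency or about how these compounds would compare at other concentrations. On these data alone, whether an amine or a carboxylic acid in place of bromo on the phenyl group, or a longer chain at the core carbon, would move the read-out beyond the scatter stays open.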